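Triazolyl for tetrazolylethyl at the chain end

The source may hold more compounds than are shown below. What is called first, only, known or untested is meant among the compounds shown, and "the series" means these compounds.

Of the compounds shown here, three sharing one core have been measured in an assay on isolated protein for inhibition of leukotriene B4 receptor 1 (Homo sapiens), tested at 10 uM; on this read-out lower numbers stand for less inhibition and higher numbers for more inhibition at the one concentration tested (going by the name of the read-out). Compound 1 `CCc1cc(C(C)=O)c(O)cc1OCCCC(C)(C)C(N)=O` gives 92%, compound 2 `CCc1cc(C(C)=O)c(O)cc1OCCCC(C)(C)c1nnn[nH]1` gives 100%, and compound 3 `CCc1cc(C(C)=O)c(O)cc1OCCCCCC(C)(C)c1nnn(C)n1` gives 95%. Compound 3 stands second highest of the three numbers, with compound 1 nearest and compound 2 furthest, both gaps within the scatter. Among the measured compounds shown here, the one measured step, a number 8 percentage points higher from compound 1 to compound 2 (within the scatter), shows that exchanging the group at the chain end left the read-out essentially unchanged. Compound 4 `CCc1cc(C(C)=O)c(O)cc1OCCCCCn1cncn1` differs from compound 3 in that (1H-1,2,4-triazol-1-yl in place of 1-methyl-1-(2-methyl-2H-tetrazol-5-yl)ethyl on a saturated chain carbon, five bonds along the chain from an oxygen on an aromatic ring). For the measured compounds named here, no measured step covers this exchange, so no change beyond the scatter is expected. Compound 4 is therefore estimated at 85%, ranging from 60% to 100%. The expected step is a number 10 percentage points lower from compound 3 to compound 4 (within the scatter).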

Compound 4, a percentage reported as inhibition, at one concentration (the size of the read-out at that concentration, not a potency): 82%
For compound 4 the middle estimate is 3 percentage points above the measured one, within the range that was stated.
By their numbers in this assay, from the lowest: compounds 4, 1, 3 and 2 (each within the scatter of the next, the first and the last beyond it).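

Among the compounds shown here, with the 1H-1,2,4-triazol-1-yl group at this chain end, this assay gives the first steps beyond the scatter, a number 13 percentage points lower from compound 3 to compound 4 (beyond the scatter) and a number 18 percentage points lower from compound 2 to compound 4 (beyond the scatter), while a number 10 percentage points lower from compound 1 to compound 4 (within the scatter) remains a smaller change. The group at the chain end therefore can shift this read-out modestly, although compound 4 still gives 82% at the one concentration tested. No available evidence accounts for the shift.

Open, as far as these compounds go, is whether a carboxylic acid or an amine at the chain end would give a number like that of compound 4 or of compound 2. Also open, from the compounds shown here alone, is how the 1H-1,2,4-triazol-1-yl group would behave on a longer chain.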